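Hydroxy replaces butyl on the chain of compound 3

The compounds below may be only part of what the source reports. "The series", "measured", "known", "first", "only" and "open" are said of these compounds alone.

Compound 1 `Cc1cc(NCc2ccc(F)cc2)c2ccccc2n1` gives 15400 nM
Compound 2 `CCCCCCCCOc1ccc2nc(C)cc(NCc3ccc(F)cc3)c2c1` gives 1800 nM
Compound 3 `CCCCCCCCCCOc1ccc2nc(C)cc(NCc3ccc(F)cc3)c2c1` gives 1900 nM

In a functional assay on MCF-10A cells (Homo sapiens) for antiproliferative activity, with a stated time of 48 h (on this read-out lower numbers stand for an effect already at smaller amounts and higher numbers for an effect only at larger amounts of compound), compound 3 gives 1900 nM and so sits within the scatter of compound 2, while compound 1 shows the clearly higher number.

Compound 4 `Cc1cc(NCc2ccc(F)cc2)c2cc(OCCCCCCO)ccc2n1` has not yet been measured. Within the data shown here, it differs from compound 3 by hydroxy in place of butyl on a saturated chain carbon, six bonds along the chain from an oxygen on an aromatic ring and no measured step makes this same exchange.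

Among the measured compounds shown here, two steps bear on it only indirectly. The step of an 8.6-fold lower number from compound 1 to compound 2 (0.93 log units; beyond the scatter) lies beyond the scatter, while the step of a 1.1-fold higher number from compound 2 to compound 3 (0.02 log units; within the scatter) stays within it. Compound 4 keeps a chain on that oxygen, so it is expected to retain part of the step of an 8.6-fold lower number from compound 1 to compound 2 (0.93 log units; beyond the scatter) and not to return fully to the number of compound 1.

A modest move to a higher number is expected, estimated as a 2.1-fold higher number from compound 3 to compound 4 (0.32 log units; beyond the scatter) in this assay overall.

For compound 4 the estimate is 4000 nM with an expected range from 1500 nM to 12000 nM in this assay as well.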

Compound 4, half-maximal effective concentration: 8100 nM
Compound 4: the middle estimate sits 2.0-fold (0.31 log units) below what was measured; the range from low to high includes it.
By their numbers in this assay, from the lowest: compounds 2 and 3 (each within the scatter of the next); then compounds 4 and 1 (each within the scatter of the next).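

In this assay the change from butyl to hydroxy gives a 4.3-fold higher number from compound 3 to compound 4 (0.63 log units; beyond the scatter) and the change from ethyl to hydroxy gives a 4.5-fold higher number from compound 2 to compound 4 (0.65 log units; beyond the scatter) at this chain carbon, six bonds along the chain from an oxygen on an aromatic ring. So the chain is not indifferent to change at this place, which the step between compound 2 and compound 3 alone did not reveal, and with (6-hydroxyhexyl)oxy in place of hydrogen there is a 1.9-fold lower number from compound 1 to compound 4 (0.28 log units; within the scatter) and the step stays within the scatter, unlike the step to the octyloxy chain. Nothing available explains this difference.

Compound 4 differs from compound 2 and compound 3 in both chain length and the hydroxy, so a plain hexyl chain on that oxygen would be needed to tell the two apart. As far as these compounds go, whether an amine or a carboxylic acid in place of the hydroxy would behave alike also remains open.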